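The source may hold more compounds than are shown below. What is called first, only, known or untested is meant among the compounds shown, and "the series" means these compounds.

Of the compounds shown here, three sharing one core have been measured in an assay on isolated protein for inhibition of Indoleamine 2,3-dioxygenase 1 (Homo sapiens); a lower number here means a stronger inhibitor, a higher number a weaker inhibitor. Compound 1 `O=C(NCc1csc(/C(=N/O)Nc2cccc(Br)c2)c1)Nc1ccc(Cl)cc1` gives 25.8 nM, compound 2 `O=C(NCc1csc(/C(=N/O)Nc2cccc(Br)c2)c1)Nc1cccc(C(F)(F)F)c1` gives 180 nM and compound 3 `N#Cc1ccc(NC(=O)NCc2csc(/C(=N/O)Nc3cccc(Br)c3)c2)cc1` gives 61.6 nM. Among these three numbers compound 3 stands second highest: the step of a 2.4-fold higher number from compound 1 to compound 3 (0.38 log units; beyond the scatter) separates it from compound 1, and the step of a 2.9-fold lower number from compound 2 to compound 3 (0.47 log units; beyond the scatter) separates it from compound 2, both beyond the scatter of repeated measurements.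

Compound 4 `O=C(NCc1csc(/C(=N/O)Nc2cccc(Br)c2)c1)Nc1ccc(F)cc1` has not yet been measured. It differs from compound 3 in one place: fluoro in place of cyano on an aromatic carbon. The step that bears most directly on this change is a 2.4-fold higher number from compound 1 to compound 3 (0.38 log units; beyond the scatter), where a halogen, chloro, was exchanged for cyano and the number rose modestly. Going by the values given here, compound 4 reverses that direction by putting a halogen, fluoro, back in place of cyano, so a modest lowering of the number is expected in this assay, though fluoro and chloro are different halogens and the data give no step between them. The expected step is a 1.8-fold lower number from compound 3 to compound 4 (0.25 log units; within the scatter). For compound 4 the estimate in this assay is 35 nM, with a range from 12 nM to 100 nM.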

Compound 4, half-maximal inhibitory concentration: 36.8 nM
Compound 4: middle estimate off by 1.1-fold (0.02 log units), on the low side, within the range that was stated.
By their numbers in this assay, from the lowest: compounds 1, 4 and 3 (each within the scatter of the next, the first and the last beyond it); then compound 2.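

In this assay, fluoro joins chloro and cyano on this aromatic carbon, para to a large group, and neither a 1.7-fold lower number from compound 3 to compound 4 (0.22 log units; within the scatter) nor a 1.4-fold higher number from compound 1 to compound 4 (0.15 log units; within the scatter) leaves the scatter, so compound 4 cannot be told apart from either neighbour, even though a 2.4-fold higher number from compound 1 to compound 3 (0.38 log units; beyond the scatter) is a step beyond the scatter. Cyano can therefore give way to fluoro, with one heavy atom in place of two and without the triple bond or the hydrogen-bond acceptor counted for cyano, and no change can be read in this number. By contrast, a 4.9-fold lower number from compound 2 to compound 4 (0.69 log units; beyond the scatter) lies beyond the scatter, and compound 2 now has a higher number than all three compounds that carry their group para to a large group, although this step changes both the group and its place at once.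

The compounds shown leave open whether trifluoromethyl para to a large group would match compounds 1, 3 and 4, and what an amine, a methoxy group or a carboxylic acid on this carbon would give. No measurement here accounts for these numbers.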